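This account rests on a few compounds, and the source may have more. Where it says the series, first, only, none or still open, it means among the compounds named here.

The compounds share one core, shown in compound 1 as `CCOC(=O)C1=C(C)N(c2ccccc2)C(C)=C(C(=O)OCC)C1c1cn(-c2ccccc2)nc1-c1ccccc1`, and are compared in an ADME assay on Vero cells (Chlorocebus sabaeus) for cytotoxicity; a higher number here means a weaker inhibitor, a lower number a stronger inhibitor. Compound 1 sits at a limit of this assay, > 10 ug/mL, rather than at a number. Compound 2, `CCOC(=O)C1=C(C)N(c2cccc(Cl)c2)C(C)=C(C(=O)OCC)C1c1cn(-c2ccccc2)nc1-c1ccccc1`, gives 7.08 ug/mL in this assay. The change an at least 1.4-fold lower number from compound 1 to compound 2 (0.14 log units; that floor lies within the scatter) is a chloro in place of hydrogen on an aromatic carbon; its floor is set by the limit of > 10 ug/mL in this assay, at which 1 of the 3 values shown sits. Compound 3, `CC(=O)C1=C(C)N(c2ccccc2)C(C)=C(C(C)=O)C1c1cn(-c2ccccc2)nc1-c1ccccc1`, carries acetyl groups in place of the esters, and in this assay compound 3 gives "not determined" (no result reported), so no number is known for it. Compound 4, `CC(=O)C1=C(C)N(c2ccccc2C)C(C)=C(C(C)=O)C1c1cn(-c2ccccc2)nc1-c1ccccc1`, differs from compound 3 by methyl in place of hydrogen on an aromatic carbon, a methyl in place of hydrogen on an aromatic carbon. For the measured compounds named here, none of the measured steps tests this exact change, and the one measured step, from compound 1 to compound 2, lies within the scatter, so no step beyond the scatter is expected in this assay. Compound 4 is therefore estimated at 8 ug/mL, between 3 ug/mL and 20 ug/mL.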

Compound 4, half-maximal inhibitory concentration: > 10 ug/mL
Compound 4: no number, only a limit; the forecaster's own chance of this, stated with the estimate: 40%; middle value at least 1.2-fold (0.09 log units) away from the limit.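

For the compounds shown here, compound 3 has no reported result in this assay, so no step from it to compound 4 can be read. Compound 4 stands at a limit, > 10 ug/mL, not at a number. What methyl in place of hydrogen does here stays open, as do the actual numbers of the compounds held at: the limit of > 10 ug/mL in this assay, at which 2 of the 4 values shown sit.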